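The source may report more compounds than this note shows. Statements on the series, on what has been measured and on what is new or still open speak of the compounds shown alone.

Series notes. Compound 1 `Cc1ccc(CN2C(=O)S/C(=C\c3ccccc3Cl)C2=O)cc1` gives 43.3% in a functional assay on the whole organism (plasma) with Mus musculus as the target, with a stated time of 15 days, at a dose of 30 mg/kg by the oral route; on this read-out lower numbers stand for a weaker effect and higher numbers for a stronger effect at the one dose given. Compound 2 `COc1ccc(/C=C2\SC(=O)N(Cc3ccc(C)cc3)C2=O)c(OC)c1` gives 34.6% in this assay. Compound 3 `Cc1ccc(CN2C(=O)S/C(=C\c3ccc(O)cc3)C2=O)cc1` gives 37.3% in this assay; on the three numbers it stands second highest, though its gaps to compound 2 and to compound 1 are both within the scatter. Going by the values given here, the one measured single-point step, a number 6 percentage points lower from compound 1 to compound 3 (within the scatter), concerns a different exchange and stayed within the scatter. Compound 4 `Cc1ccc(CN2C(=O)S/C(=C\c3ccc([N+](=O)[O-])cc3)C2=O)cc1` is not yet measured; relative to compound 3 it carries nitro in place of hydroxy on an aromatic carbon. Among the compounds with values here, no measured step exchanges hydroxy for nitro, so nothing bears on it directly. For compound 4 no step beyond the scatter is expected, a number 0.7 percentage points higher from compound 3 to compound 4 (within the scatter). Compound 4 is thus estimated at 38%, with a range from 25% to 51%.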

Compound 4, a percentage reported as activity, at one dose (the size of the read-out at that dose, not a potency): 11.4%
Estimate against measurement, compound 4: 26.6 percentage points above, and the stated range ends above it.
By their numbers in this assay, from the lowest: compound 4; then compounds 2, 3 and 1 (each within the scatter of the next).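

Going by these compounds alone, this position, para to a large group, does not tolerate every exchange in this assay: nitro in place of hydroxy gives a number 25.9 percentage points lower from compound 3 to compound 4 (beyond the scatter), the only step beyond the scatter. The other measured step, a number 6 percentage points lower from compound 1 to compound 3 (within the scatter), stayed within it. Nothing measured here accounts for this drop.

From the compounds shown here alone, whether the drop follows from the arrival of nitro or the loss of hydroxy stays open. An amine or a carboxylic acid at this position could help separate the two.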